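Swapping chloro for methoxy on the anilino ring of compound 1

The source may report more compounds than this note shows. Statements on the series, on what has been measured and on what is new or still open speak of the compounds shown alone.

Measured compounds:
- Compound 1, `Cc1cc(Nc2cc(N3CCN(C)CC3)nc(Nc3cccc(Cl)c3)n2)n[nH]1`: 1770 nM
- Compound 2, `Cc1cc(Nc2cc(N3CCN(C)CC3)nc(Nc3ccc(Cl)cc3)n2)n[nH]1`: 7470 nM

Both compounds were tested in a functional assay on NCI-N87 cells (Homo sapiens) for antiproliferative activity, read by CCK-8 assay, with a stated time of 72 h; a higher number here means a weaker inhibitor, a lower number a stronger inhibitor. Within the data shown here, compound 1 holds the lowest of the two numbers; its only neighbour is compound 2, which differs from it by the single step of a 4.2-fold higher number from compound 1 to compound 2 (0.63 log units; beyond the scatter), a shift that lies beyond the scatter.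

Compound 3, `COc1cccc(Nc2nc(Nc3cc(C)[nH]n3)cc(N3CCN(C)CC3)n2)c1`, has not yet been measured. It differs from compound 1 by methoxy in place of chloro on an aromatic carbon. Among the measured compounds shown here, the sole measured step, a 4.2-fold higher number from compound 1 to compound 2 (0.63 log units; beyond the scatter), concerns a change of position for the same chloro group rather than an exchange of one group for another, so it bears on the present change only loosely: it shows that this position on the ring is sensitive to what sits there, but it gives no direct guide to the size or direction of replacing chloro with methoxy. A modest step in this assay is therefore expected, most likely a small rise, with a wide uncertainty. Compound 3 is estimated at 2600 nM, within a range from 800 nM to 8500 nM, which corresponds to an expected step of a 1.5-fold higher number from compound 1 to compound 3 (0.17 log units; within the scatter).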

Compound 3, half-maximal inhibitory concentration: 7190 nM
Beside the measured number, compound 3's estimate is 2.8-fold (0.44 log units) below it; the range from low to high includes it.
By their numbers in this assay, from the lowest: compound 1; then compounds 3 and 2 (each within the scatter of the next).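

In this assay, exchanging chloro for methoxy on this ring gives a 4.1-fold higher number from compound 1 to compound 3 (0.61 log units; beyond the scatter), so this place responds to a change of group as well as to the shift of chloro that separates compound 1 from compound 2. The 3-methoxyphenyl of compound 3 and the 4-chlorophenyl of compound 2 stand level, with a 1.0-fold lower number from compound 2 to compound 3 (0.02 log units; within the scatter), which leaves the 3-chlorophenyl of compound 1 as the only one of the three set apart, its steps to both others lying beyond the scatter. The numbers show the size of the methoxy step but not what lies behind it, and no supporting measurement bears on this result.

The compounds shown leave open whether another group at this place, such as fluoro, methyl or an amine, would match compound 1 or give a lower number still. They also leave open whether 4-methoxyphenyl would track 4-chlorophenyl, and whether the gap between chloro and methoxy would hold with a different group elsewhere on the shared core.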